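The source may hold more compounds than are shown below. What is called first, only, known or untested is meant among the compounds shown, and "the series" means these compounds.

Three compounds share one core and differ only in the aromatic group attached to a saturated ring carbon of a five-membered ring. Compound 1 `Cc1cccc(C2(CNC(=O)Nc3c(C(C)C)cccc3C(C)C)CCCC2)c1` gives 15 nM in an assay on microsomes for inhibition of acyl-CoA:cholesterol acyltransferase (Oryctolagus cuniculus); on this read-out higher numbers stand for weaker inhibition and lower numbers for stronger inhibition; compound 2 `CC(C)c1cccc(C(C)C)c1NC(=O)NCC1(c2ccc(Cl)cc2)CCCC1` gives 32 nM in this assay; and compound 3 `CC(C)c1cccc(C(C)C)c1NC(=O)NCC1(c2ccc(C(F)(F)F)cc2)CCCC1` gives 66 nM in this assay, the highest of the three numbers. The measured steps are a 2.1-fold higher number from compound 1 to compound 2 (0.33 log units; beyond the scatter), a 2.1-fold higher number from compound 2 to compound 3 (0.31 log units; beyond the scatter) and a 4.4-fold higher number from compound 1 to compound 3 (0.64 log units; beyond the scatter). Compound 4 `CC(C)c1cccc(C(C)C)c1NC(=O)NCC1(c2cccc([N+](=O)[O-])c2)CCCC1` differs from compound 3 by 3-nitrophenyl in place of 4-(trifluoromethyl)phenyl on a saturated ring carbon. Going by the values given here, no measured step introduces a nitro group, so the only guide is that compound 1, which carries 3-methylphenyl, gave the lowest number. A modest move toward lower numbers is therefore expected, with wide uncertainty, a 2.2-fold lower number from compound 3 to compound 4 (0.34 log units; beyond the scatter). Compound 4 is estimated at 30 nM, within a range from 10 nM to 100 nM.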

Compound 4, half-maximal inhibitory concentration: 51 nM
Compound 4: middle estimate off by 1.7-fold (0.23 log units), on the low side; the measured number falls inside the stated range.
By their numbers in this assay, from the lowest: compound 1; then compounds 2, 4 and 3 (each within the scatter of the next, the first and the last beyond it).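

With 3-nitrophenyl on the saturated ring carbon, the result is a 1.3-fold lower number from compound 3 to compound 4 (0.11 log units; within the scatter) and a 1.6-fold higher number from compound 2 to compound 4 (0.20 log units; within the scatter) so this group cannot be told apart from 4-(trifluoromethyl)phenyl or 4-chlorophenyl. The step that stands out is a 3.4-fold higher number from compound 1 to compound 4 (0.53 log units; beyond the scatter) and it shows that a group at the 3 position of the phenyl ring does not by itself keep the low number of compound 1, since nitro in place of methyl loses it. Nothing measured here gives a reason for this. On these data alone, whether 3-aminophenyl or 3-methoxyphenyl would stay near compound 1 remains open, as does whether any other group on this carbon would give a lower number than compound 1.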